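Swapping methyl for chloro on compound 2

A few compounds are considered here, and "the series" means these few. Any claim that something is new, unique, unknown or untested is made for them only; others in the source may bear on it.

Compound 1 (`COc1ccc(-c2cc(=O)c3ccc(F)cc3o2)cc1OC`) gives 27900 nM
Compound 2 (`COc1ccc(-c2nc3cc(F)ccc3s2)cc1C`) gives 48 nM

In a functional assay on MCF7 cells (Homo sapiens) for inhibition (a lower number here means a stronger inhibitor, a higher number a weaker inhibitor), compound 2 has the lower of the two numbers, and its gap to compound 1 lies beyond the usual scatter. Compound 3 (`COc1ccc(-c2nc3cc(F)ccc3s2)cc1Cl`) differs from compound 2 in one place (chloro in place of methyl on an aromatic carbon): chloro in place of methyl on an aromatic carbon, ortho to a methoxy group. Within the data shown here, no measured pair shows this swap, so the guide is thin, and no step beyond the scatter is expected in this assay here. The estimate means only a small expected change (a 1.1-fold lower number from compound 2 to compound 3 (0.03 log units; within the scatter)) in either direction. Compound 3 is estimated at 45 nM (expected range 15 nM to 150 nM) in this measurement.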

Compound 3, half-maximal inhibitory concentration: 760 nM
For compound 3 the middle estimate is 17-fold (1.23 log units) below the measured one; the measured number lies above the stated range.
By their numbers in this assay, from the lowest: compound 2; then compound 3; then compound 1.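

In this assay, chloro in place of methyl ortho to a methoxy group gives a 16-fold higher number from compound 2 to compound 3 (1.20 log units; beyond the scatter) and so shows that this position responds strongly to a change of a single heavy atom. The two groups match in the counts of hydrogen-bond donors, acceptors and charge, yet the swap is beyond the scatter, which the comparison of compound 1 with compound 2, differing in more than one place, could not reveal. No measurement shown explains this step.

From the compounds shown here alone, whether bromo, ethyl, a nitrile or an amine at this position would keep the activity of compound 2 remains open.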